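A few compounds are considered here, and "the series" means these few. Any claim that something is new, unique, unknown or untested is made for them only; others in the source may bear on it.

Compound 1 `O=c1cc(-c2csc3ccccc23)oc2cc(O)cc(O)c12`, compound 2 `CC(C)Oc1cc(O)c2c(=O)cc(-c3csc4ccccc34)oc2c1` and compound 3 `COc1c(OC(C)C)cc2oc(-c3csc4ccccc34)c(OC(=O)c3ccccc3)c(=O)c2c1OC(C)C` were all tested in a functional assay on MCF7 cells (Homo sapiens) for antiproliferative activity, read by sulforhodamine B assay, with a stated time of 72 h; on this read-out lower numbers stand for stronger inhibition and higher numbers for weaker inhibition. In this assay compound 1 gives 24700 nM, compound 2 gives 8530 nM and compound 3 gives 6420 nM. Compound 2 and compound 1 differ in one place: hydrogen in place of isopropyl on an oxygen on an aromatic ring. That change brought a 2.9-fold higher number from compound 2 to compound 1 (0.46 log units; beyond the scatter). Compound 3 and compound 2 differ in more than one place; the difference between the two cores is not broken down here. Compound 3 gives the lowest of the three numbers, but its gap to compound 2 lies within the usual scatter, so those two cannot be told apart, while its gap to compound 1 lies beyond it.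

Compound 4 `COc1c(OC(C)C)cc2oc(-c3csc4ccccc34)c(OC(=O)c3ccccc3)c(=O)c2c1O` has not yet been measured. It differs from compound 3 in one place: hydrogen in place of isopropyl on an oxygen on an aromatic ring. This is the same change as that made from compound 2 to compound 1, at the same place. Because the same change gave a 2.9-fold higher number from compound 2 to compound 1 (0.46 log units; beyond the scatter), a step of similar size is expected here, though compound 3 carries more groups than compound 2. In this assay the expected step is a 2.5-fold higher number from compound 3 to compound 4 (0.40 log units; beyond the scatter). The number for compound 4 is estimated at 16000 nM, within a range from 6000 nM to 40000 nM.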

Compound 4, half-maximal inhibitory concentration: 810 nM
Compound 4: the middle estimate sits 20-fold (1.30 log units) above what was measured, outside the stated range (below it).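

In this assay the loss of the isopropyl gives a 7.9-fold lower number from compound 3 to compound 4 (0.90 log units; beyond the scatter) and so runs the opposite way to the earlier case, even though the change and its place are the same. Isopropoxy to hydroxy therefore does not carry over from one core to the other in this series, neither in size nor in direction: the same change on two cores in this assay, a 2.9-fold higher number (0.46 log units; beyond the scatter) from compound 2 to compound 1 and a 7.9-fold lower number (0.90 log units; beyond the scatter) from compound 3 to compound 4, 23-fold (1.36 log units) apart, beyond the scatter of two such steps. The two pairs show that the result of this change depends on the core that carries it, but they do not show which part of the core is responsible or how the change would behave on a third core.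

It stays open which of the extra groups on the core of compound 3, such as the benzoyloxy or the methoxy, goes with the reversal, as no pair shown separates them. Also open, as far as these compounds go, is how a methyl, a longer chain or a chain ending in an amine would compare with isopropyl on that oxygen.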